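Thienyl pyrazoline series: cyano to chloro on the phenyl arm

The compounds below may be only part of what the source reports. "The series", "measured", "known", "first", "only" and "open" are said of these compounds alone.

Measured so far:
compound 1, `Fc1ccc(C2CC(c3ccc(Cl)s3)=NN2c2nc(-c3ccc(Cl)cc3)cs2)cc1`: 125 ug/mL
compound 2, `N#Cc1ccc(-c2csc(N3N=C(c4ccc(Cl)s4)CC3c3ccc(F)cc3)n2)cc1`: > 500 ug/mL
compound 3, `Cc1ccc(C2=NN(c3nc(-c4ccc(C#N)cc4)cs3)C(c3ccc(F)cc3)C2)s1`: 322 ug/mL

In a functional assay on A549 cells (Homo sapiens) for antiproliferative activity, read by XTT assay, with a stated time of 24 h (on this read-out lower numbers stand for stronger inhibition and higher numbers for weaker inhibition), compound 1 gives 125 ug/mL. For compound 2 the result is a limit of the assay, > 500 ug/mL, not a number; one of the three values sits at the limit of > 500 ug/mL in this assay, at which 1 of the 3 values shown sits. Compound 3 gives 322 ug/mL, the highest number among the two numbers shown.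

The change chloro in place of cyano on an aromatic carbon gave an at least 4.0-fold lower number from compound 2 to compound 1 (0.60 log units; beyond the scatter). The cores of compound 2 and compound 3 differ by methyl in place of chloro on an aromatic carbon, which gave an at least 1.5-fold lower number from compound 2 to compound 3 (0.19 log units; that floor lies within the scatter).

Compound 4, `Cc1ccc(C2=NN(c3nc(-c4ccc(Cl)cc4)cs3)C(c3ccc(F)cc3)C2)s1`, is to be measured in this assay. It differs from compound 3 by chloro in place of cyano on an aromatic carbon; the place is described in the same words as for the step from compound 2 to compound 1, so this is the same change. Resting on that earlier step, an at least 4.0-fold lower number from compound 2 to compound 1 (0.60 log units; beyond the scatter), the expected step from compound 3 to compound 4 is a 3.6-fold lower number from compound 3 to compound 4 (0.55 log units; beyond the scatter). Compound 4 is therefore estimated at 90 ug/mL, with a range from 40 ug/mL to 250 ug/mL.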

Compound 4, half-maximal inhibitory concentration: > 500 ug/mL
Compound 4: a limit, no number (the forecaster's own chance of this, stated with the estimate: 5%); at least 5.5-fold (0.74 log units) between middle value and limit.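

In this assay compound 4 gives > 500 ug/mL, which is a limit and not a number, and it shares that limit with compound 2: the limit of > 500 ug/mL in this assay, at which 2 of the 4 values shown sit.

Chloro in place of cyano, which here gives an at least 1.5-fold higher number from compound 3 to compound 4 (0.19 log units; that floor lies within the scatter), does not repeat its earlier effect on the other core: the same change on two cores in this assay, an at least 4.0-fold lower number (0.60 log units; beyond the scatter) from compound 2 to compound 1 and an at least 1.5-fold higher number (0.19 log units; that floor lies within the scatter) from compound 3 to compound 4, at least 6.2-fold (0.79 log units) apart, beyond the scatter of two such steps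

Methyl in place of chloro, which here gives an at least 4.0-fold higher number from compound 1 to compound 4 (0.60 log units; beyond the scatter), also differs between the two cores, so neither change carries from one core to the other in this set, though with only floors available the true size of each step is not shown, nor is any rule for the wider series: the same change on two cores in this assay, an at least 1.5-fold lower number (0.19 log units; that floor lies within the scatter) from compound 2 to compound 3 and an at least 4.0-fold higher number (0.60 log units; beyond the scatter) from compound 1 to compound 4, at least 6.2-fold (0.79 log units) apart, beyond the scatter of two such steps

Still open, going by these compounds, is how an amine or a carboxylic acid would read at the aromatic carbon that holds chloro or cyano. Also open, on these data alone, is whether a longer chain in place of the methyl of compound 3 would give a number rather than a limit.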